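Furan for methoxyphenyl on a quinoxaline dioxide nitrile

The source may hold more compounds than are shown below. What is called first, only, known or untested is meant among the compounds shown, and "the series" means these compounds.

The measured compounds:
compound 1, `N#Cc1c(-c2ccco2)[n+]([O-])c2ccc(C(F)(F)F)cc2[n+]1[O-]`, gives 1.5 in a physicochemical assay for lipophilicity, measured as octanol-water partition; a lower number here means a more polar compound, a higher number a more lipophilic compound.
compound 2, `COc1ccc(-c2c(C#N)[n+]([O-])c3cc(C(F)(F)F)ccc3[n+]2[O-])cc1`, gives 2.45 in this assay.
compound 3, `COc1ccc(-c2c(C#N)[n+]([O-])c3cc(Cl)c(Cl)cc3[n+]2[O-])cc1`, gives 2.33 in this assay.

Compound 2 and compound 1 share a core and differ in one place: furan-2-yl in place of 4-methoxyphenyl on an aromatic carbon. That change made a step of a number 0.95 log units lower from compound 2 to compound 1 (beyond the scatter) in this assay.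

Compound 3 carries a different core; how the core of compound 3 differs from the core of compound 2 is not broken down here. The values of compound 2 and compound 3 in this assay lie within the scatter of each other.

Compound 4, `N#Cc1c(-c2ccco2)[n+]([O-])c2cc(Cl)c(Cl)cc2[n+]1[O-]`, has not yet been measured. It stands to compound 3 as compound 1 stands to compound 2: furan-2-yl in place of 4-methoxyphenyl on an aromatic carbon. The surroundings of the place are the same in both pairs, so this is the same change. The step in this assay is therefore expected to be about as large as in that earlier pair, namely a number 0.95 log units lower from compound 3 to compound 4 (beyond the scatter). This rests on a single earlier occurrence, so the expectation is loose. Compound 4 is expected to give about 1.38 in this assay, most likely between 0.95 and 1.8.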

Compound 4, partition coefficient: 1.64
Beside the measured number, compound 4's estimate is 0.26 log units below it, and the stated range covers the measured number.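

Carrying furan-2-yl in place of 4-methoxyphenyl over to a second core gave, in this assay, a step of the same direction: a number 0.69 log units lower from compound 3 to compound 4 (beyond the scatter) on that core, after a number 0.95 log units lower from compound 2 to compound 1 (beyond the scatter) on the first. The change therefore kept its direction in both pairs, the only two shown, and this says nothing yet about how it would behave on any further core. Nothing available here bears on why the step runs this way or takes this size.

The compounds shown leave open how an amine, a carboxylic acid or a longer chain on that same aromatic carbon, next to the ring nitrogen, would read in this assay on either core. They also leave open whether the nitrile that sits ortho to this place has any part in the step, since every compound here carries it.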